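This account rests on a few compounds, and the source may have more. Where it says the series, first, only, none or still open, it means among the compounds named here.

In an assay on microsomes from brain for inhibition of Fatty-acid amide hydrolase 1 (Rattus norvegicus), read by fluorescence and HPLC, with a stated time of 60 min (on this read-out lower numbers stand for stronger inhibition and higher numbers for weaker inhibition), compound 3 `CCCCCCCCc1ccc(OCC(=O)Cn2nnnc2-c2ccncc2)cc1` gives 190 nM, the second highest of the three numbers recorded so far: compound 1 `CCCCCCCCc1ccc(OCC(=O)Cn2nnc(SC)n2)cc1` gives 31 nM, while compound 2 `CCCCCCCCc1ccc(OCC(=O)Cn2nnnc2-c2ccccc2Cl)cc1` gives 4600 nM. Compound 4 `CCCCCCCCc1ccc(OCC(=O)Cn2nnnc2C(=O)OC)cc1` carries methoxycarbonyl in place of pyridin-4-yl on an aromatic carbon. Going by the values given here, the only measured step bearing on this place is a 24-fold lower number from compound 2 to compound 3 (1.38 log units; beyond the scatter), which shows that the group there moves the number strongly. Among the compounds with values here, compound 1, with methylthio at the same place, stands further beneath compound 3 than compound 2 stands above it, though no single step joins compound 1 to compound 3. Exchanging pyridin-4-yl for methoxycarbonyl is therefore expected to lower the number by a 3.2-fold lower number from compound 3 to compound 4 (0.50 log units; beyond the scatter). For compound 4 the estimate is 60 nM, expected to lie between 15 nM and 300 nM.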

Compound 4, half-maximal inhibitory concentration: 1000 nM
Beside the measured number, compound 4's estimate is 17-fold (1.22 log units) below it, and the stated range ends below it.
By their numbers in this assay, from the lowest: compound 1; then compound 3; then compound 4; then compound 2.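

Methoxycarbonyl at this place gives a 5.3-fold higher number from compound 3 to compound 4 (0.72 log units; beyond the scatter) and a 4.6-fold lower number from compound 2 to compound 4 (0.66 log units; beyond the scatter), so in this assay this group without a ring falls between pyridin-4-yl and 2-chlorophenyl. The exchange of the whole substituted ring gives a 32-fold higher number from compound 1 to compound 4 (1.51 log units; beyond the scatter), but that step changes the ring attachment along with the group, so it cannot be credited to methoxycarbonyl alone. Nothing available here accounts for these shifts. The compounds shown leave open whether a carboxylic acid or an amide at this place stands nearer compound 1 or compound 4, and whether methylthio keeps its low number with the ring attached as in compound 4.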